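Swapping the fluorophenyl on the saturated ring carbon

A few compounds are considered here, and "the series" means these few. Any claim that something is new, unique, unknown or untested is made for them only; others in the source may bear on it.

Measured compounds and their values:
compound 1, `COc1ccc(C2=NN(C(=O)c3ccc4c(c3)OCCO4)C(c3ccc(F)cc3)C2)cc1`: 3780 nM
compound 2, `COc1ccc(C2CC(c3ccc(Br)cc3)=NN2C(=O)C2COc3ccccc3O2)cc1`: 9010 nM
compound 3, `O=C(c1ccc2c(c1)OCCO2)N1N=C(c2ccccc2)CC1c1ccccc1F`: 2500 nM

All three were tested in a functional assay on WM 266-4 cells (Homo sapiens) for inhibition, read by MTT assay, with a stated time of 24 h; on this read-out higher numbers stand for weaker inhibition of growth and lower numbers for stronger inhibition of growth. Compound 3 has the lowest of the three numbers; compound 1 sits within the usual scatter of it, while compound 2 lies beyond. Within the data shown here, no two measured compounds differ in a single place, so no single change has a measured size here.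

Compound 4 `O=C(c1ccc2c(c1)OCCO2)N1N=C(c2ccccc2)CC1c1ccc(F)cc1` differs from compound 3 only in this way: 4-fluorophenyl in place of 2-fluorophenyl on a saturated ring carbon. Compound 1 also carries a 4-fluorophenyl there and gives 3780 nM, but it differs from compound 4 elsewhere too. The step of a 1.3-fold higher number from compound 3 to compound 4 (0.12 log units; within the scatter) is expected to stay within the scatter, with no clear direction. Compound 4 is expected to give about 3300 nM, within a range from 1400 nM to 8000 nM.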

Compound 4, concentration for 50% growth inhibition: 5210 nM
The estimate for compound 4 lay 1.6-fold (0.20 log units) below the measured number; the range from low to high includes it.
By their numbers in this assay, from the lowest: compounds 3, 1, 4 and 2 (each within the scatter of the next, the first and the last beyond it).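

Here the position of the fluorine on this phenyl makes a modest difference: 4-fluorophenyl in place of 2-fluorophenyl on the saturated ring carbon gives a 2.1-fold higher number from compound 3 to compound 4 (0.32 log units; beyond the scatter). Hydrogen in place of methoxy on an aromatic carbon gives a 1.4-fold higher number from compound 1 to compound 4 (0.14 log units; within the scatter), so that change shows no clear effect. Nothing available explains the fluorine step.

The compounds shown leave open how a phenyl carrying an amine or a carboxylic acid, or a simple methyl, would behave on this carbon. From the compounds shown here alone, whether the fluorine step recurs on another core also remains open.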